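The compounds below may be only part of what the source reports. "The series", "measured", "known", "first", "only" and "open" are said of these compounds alone.

Among the measured compounds shown here, in an assay on HL-60 cells for agonist activity at N-formyl peptide receptor 3 (Homo sapiens), read by calcium flux (on this read-out lower numbers stand for an effect already at smaller amounts and higher numbers for an effect only at larger amounts of compound), the three compounds measured so far all rest on the same limit of the assay. Compound 1, `COc1ccc(Cc2cc(-c3ccc(F)cc3)nn(CC(=O)Nc3ccc(Br)cc3)c2=O)cc1`, gives > 50000 nM, which is a limit and not a number. Compound 2, `COc1ccc(Cc2cc(Cc3ccccc3)nn(CC(=O)Nc3ccc(Br)cc3)c2=O)cc1`, gives > 50000 nM, again a limit. Compound 3, `Cc1cc(Cc2cccc(Br)c2)c(=O)n(CC(=O)Nc2ccc(Br)cc2)n1`, gives > 50000 nM, once more a limit. For the measured compounds named here, the one step between compounds that differ in a single place, a step that the two limits leave unreadable from compound 1 to compound 2, therefore cannot be read in size or direction; the only evidence on the measured steps is the limit of > 50000 nM in this assay, at which 3 of the 3 values shown sit.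

The next compound, compound 4, `Cc1cc(Cc2ccsc2)c(=O)n(CC(=O)Nc2ccc(Br)cc2)n1`, differs from compound 3 by thiophen-3-yl in place of 3-bromophenyl on a saturated chain carbon bound to an aromatic carbon. Going by the values given here, no measured step touches this kind of exchange, and the step from compound 1 to compound 2, the only one recorded, is itself hidden by the two limits. Compound 3 stands at the limit, so there is no number from which a step could be counted. With nothing pointing toward a shift beyond the scatter, compound 4 is expected to stay where compound 3 stands, the expected step being a number no higher from compound 3 to compound 4 (the limit leaves the size open). Compound 4 is therefore estimated at 50000 nM in this assay, within a range from 15000 nM to 200000 nM, with a real chance that the assay again returns only a limit.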

Compound 4, half-maximal effective concentration: > 50000 nM
Compound 4: no number, only a limit; the forecaster's own chance of this, stated with the estimate: 85%; the middle value sits exactly at the limit.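

In this assay compound 4 gives > 50000 nM, which is a limit and not a number. Compound 3 also rests on a limit, so the exchange between compound 3 and compound 4 yields no readable step. The compounds shown leave open which structural change, if any, would give a measurable value: the limit of > 50000 nM in this assay, at which 4 of the 4 values shown sit.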